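The source may report more compounds than this note shows. Statements on the series, on what has been measured and on what is new or still open speak of the compounds shown alone.

Working notes on the series. The shared core of compound 2 `CN(C)C(=O)CCSC(SCCC(=O)O)c1cccc(OCc2ccc3ccc(Cl)cc3n2)c1` carries a chain with a carboxylic acid on a sulfur and, on the same saturated chain carbon, the (2-(dimethylcarbamoyl)ethyl)sulfanyl group. In an assay on membranes from lung for binding affinity to cysteinyl leukotriene receptor 1 (Cavia porcellus) (on this read-out lower numbers stand for stronger inhibition and higher numbers for weaker inhibition), compound 2 gives 14 nM, the highest of the three numbers measured. Among the compounds with values here, compound 1 `CCC(CSC(CCc1ccccc1C#N)c1cccc(CCc2ccc3ccc(Cl)cc3n2)c1)C(=O)O` gives 1 nM in this assay and compound 3 `CCC(CSC(CCc1ccccc1-c1nnnn1C)c1cccc(OCc2ccc3ccc(Cl)cc3n2)c1)C(=O)O` gives 0.4 nM; both differ from compound 2 in more than one place, so their values show only that markedly lower numbers are reached.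

Compound 4 `O=C(O)CCSC(CCc1ccccc1)c1cccc(OCc2ccc3ccc(Cl)cc3n2)c1` is not yet measured. It differs from compound 2 by a single change: phenethyl in place of (2-(dimethylcarbamoyl)ethyl)sulfanyl on a saturated chain carbon bound to an aromatic carbon and a sulfur.

Within the data shown here, because compound 1 gives 1 nM and compound 3 gives 0.4 nM while compound 2 gives 14 nM, a step toward lower numbers beyond the scatter is expected for compound 4, though the size is uncertain as no single-change step is available. The estimated step from compound 2 to compound 4 is a 4.7-fold lower number from compound 2 to compound 4 (0.67 log units; beyond the scatter). For compound 4 the estimate in this assay is 3 nM, with a range from 0.8 nM to 12 nM.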

Compound 4, half-maximal inhibitory concentration: 6.5 nM
The estimate for compound 4 lay 2.2-fold (0.34 log units) below the measured number; measured number inside the range.
By their numbers in this assay, from the lowest: compound 3; then compound 1; then compound 4; then compound 2.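

At a saturated chain carbon bound to an aromatic carbon and a sulfur, the series now has its first single-change step: phenethyl in place of (2-(dimethylcarbamoyl)ethyl)sulfanyl gives a 2.2-fold lower number from compound 2 to compound 4 (0.33 log units; beyond the scatter) in this assay, a modest move. The amide and the sulfur of the departing group are therefore not required at this position for a low number, since an all-carbon group of equal heavy-atom count, bearing a six-membered aromatic ring, does not raise it. Nothing shown here speaks to the origin of this step.

From the compounds shown here alone, whether the step depends on the aromatic ring of phenethyl or on its chain stays open, and a 2-cyclohexylethyl or a benzyl group at this place would help separate the two. Going by these compounds, whether the same change carries over to the cores of compound 1 and compound 3 also stays open.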